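Swapping a Ring-Bearing Group for a Ring-Free One

This account rests on a few compounds, and the source may have more. Where it says the series, first, only, none or still open, it means among the compounds named here.

Measured in a functional assay on HeLa cells (Homo sapiens) for inhibition, read by MTT assay, with a stated time of 48 h; on this read-out lower numbers stand for stronger inhibition and higher numbers for weaker inhibition:
- compound 1 `CCOC(=O)C1=C(N/N=C(/C(=O)Br)c2ccc(Br)cc2)Nc2[nH]nc(C)c2C1c1ccc(N(C)C)cc1`: 68500 nM
- compound 2 `CCOC(=O)C1=C(N/C=N/c2ccccn2)Nc2[nH]nc(C)c2C1c1ccc(N(C)C)cc1`: 29200 nM

Not yet measured:
- compound 3 `CCOC(=O)C(=NNC1=C(C(=O)OCC)C(c2ccc(N(C)C)cc2)c2c(C)n[nH]c2N1)C(=O)OCC`

Of the two measured compounds, compound 2 stands lowest at 29200 nM, making it the stronger inhibitor of the pair. Compound 3 keeps the core of compound 2 and differs in one place, an amine nitrogen whose other neighbour is a double-bonded ring carbon. The change is a group of 12 heavy atoms (7 carbon, 1 nitrogen, 4 oxygen; no ring) in place of a group of 8 heavy atoms (6 carbon, 2 nitrogen; one six-membered aromatic ring with 1 hetero atom), on an amine nitrogen. The group that leaves holds one six-membered aromatic ring with 1 hetero atom, and the group that enters has no ring.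

Among the measured compounds shown here, only one measured step bears on this: a 2.3-fold lower number from compound 1 to compound 2 (0.37 log units; beyond the scatter). It is modest but beyond the scatter, and it also exchanges a group of 12 heavy atoms and a group of 8 heavy atoms on an amine nitrogen. Compound 1 carries a different group of 12 heavy atoms, so this is thin support. In this assay, a modest rise is expected, smaller than that step: a 1.5-fold higher number from compound 2 to compound 3 (0.19 log units; within the scatter). Compound 3 is estimated at 45000 nM, with an expected range from 18000 nM to 110000 nM.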

Compound 3, half-maximal inhibitory concentration: 83800 nM
Compound 3: middle estimate off by 1.9-fold (0.27 log units), on the low side, and the stated range covers the measured number.
By their numbers in this assay, from the lowest: compound 2; then compounds 1 and 3 (each within the scatter of the next).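

In this assay, the step of a 2.9-fold higher number from compound 2 to compound 3 (0.46 log units; beyond the scatter) lies beyond the scatter, so the group of 8 heavy atoms with its six-membered aromatic ring with 1 hetero atom now stands apart from two different groups of 12 heavy atoms on this amine nitrogen, not just one. Those two larger groups are not told apart, since a 1.2-fold higher number from compound 1 to compound 3 (0.09 log units; within the scatter) lies within the scatter, even though one holds a six-membered aromatic ring of carbon only and two bromine atoms and the other has no ring and more hydrogen-bond acceptors. No measurement offered here accounts for these differences.

Among these compounds, the group that gives the lowest number differs from the other two in both its size and its ring, so the shown data cannot separate the contribution of either feature. As far as these compounds go, it remains open whether the lower number would persist with a plain phenyl ring in place of the ring holding the hetero atom, or whether a free carboxylic acid in place of the ethyl esters of compound 3 would shift the number at all.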